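A few compounds are considered here, and "the series" means these few. Any claim that something is new, unique, unknown or untested is made for them only; others in the source may bear on it.

For the measured compounds named here, in a functional assay on MV4-11 cells (Homo sapiens) for antiproliferative activity, read by CCK-8 assay, with a stated time of 72 h (a lower number here means a stronger inhibitor, a higher number a weaker inhibitor), compound 3 `Cn1cc(-c2cc(C(C)(C)O)ccc2Oc2ccc(F)cc2F)c2cc(C(=O)NCc3ccc(C(=O)NO)cc3)[nH]c2c1=O` gives 190 nM, the middle of the three numbers measured so far. Compound 2 `Cn1cc(-c2cc(C(C)(C)O)ccc2OC2CC2)c2cc(C(=O)NCc3ccc(C(=O)NO)cc3)[nH]c2c1=O` sits higher at 420 nM, and compound 1 `CC(C)Oc1ccc(C(C)(C)O)cc1-c1cn(C)c(=O)c2[nH]c(C(=O)NCc3ccc(C(=O)Nc4ccccc4N)cc3)cc12` sits lower at 40 nM.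

The next molecule, compound 4 `CC(C)Oc1ccc(C(C)(C)O)cc1-c1cn(C)c(=O)c2[nH]c(C(=O)NCc3ccc(C(=O)NO)cc3)cc12`, keeps compound 3 unchanged except for one group: isopropyl in place of 2,4-difluorophenyl on an oxygen on an aromatic ring. In counted terms, the change is isopropyl in place of 2,4-difluorophenyl on an oxygen on an aromatic ring.

Going by the values given here, only one measured step bears directly on this place: a 2.2-fold lower number from compound 2 to compound 3 (0.34 log units; beyond the scatter), a modest gain when cyclopropyl gave way to 2,4-difluorophenyl. Compound 4 goes the other way, from that aromatic group back to a small alkyl group. The step seen with compound 2 therefore suggests a modest move towards a higher number in this assay, perhaps no larger than the scatter.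

Among the compounds with values here, compound 1 also has isopropyl on that oxygen, but it differs from compound 4 elsewhere too, so it gives no clean step. Its low number only argues against placing the estimate far above the value for compound 2.

The estimated change is a 1.6-fold higher number from compound 3 to compound 4 (0.20 log units; within the scatter).

For compound 4, the expected value is 300 nM, with an estimated range from 110 nM to 650 nM.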

Compound 4, half-maximal inhibitory concentration: 350 nM
Compound 4: the middle estimate sits 1.2-fold (0.07 log units) below what was measured; measured number inside the range.
By their numbers in this assay, from the lowest: compound 1; then compounds 3, 4 and 2 (each within the scatter of the next, the first and the last beyond it).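

On the oxygen, in this assay, replacing the aromatic group with isopropyl gives a 1.8-fold higher number from compound 3 to compound 4 (0.27 log units; within the scatter) and replacing cyclopropyl with isopropyl gives a 1.2-fold lower number from compound 2 to compound 4 (0.08 log units; within the scatter) so isopropyl cannot be told apart from either group, even though the step of a 2.2-fold lower number from compound 2 to compound 3 (0.34 log units; beyond the scatter) separates those two from each other. The earlier compounds shown here offered no clean reading of the other end of the molecule, whereas the pair now available shows an 8.8-fold higher number from compound 1 to compound 4 (0.94 log units; beyond the scatter) when hydroxy replaces 2-aminophenyl on the amide-type nitrogen, a much larger move than any seen on the oxygen in these compounds. No measurement shown here explains either the small steps on the oxygen or the large step on the amide-type nitrogen.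

Still open, on these data alone, is whether 2-aminophenyl on the amide-type nitrogen would give a similar result alongside cyclopropyl or 2,4-difluorophenyl on the oxygen, as it appears here only with isopropyl. Also open, as far as these compounds go, is how a longer alkyl chain or a benzyl group on that oxygen would read, and how a methyl group or an unsubstituted phenyl ring on the amide-type nitrogen would compare.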